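Swapping a Fluorophenyl for Pyridin-2-yl on the Sulfonamide

The source may hold more compounds than are shown below. What is called first, only, known or untested is meant among the compounds shown, and "the series" means these compounds.

Three compounds share one core and differ only in the ring carried on the saturated chain carbon bound to the sulfonamide nitrogen. In an assay on isolated protein for inhibition of protein deacetylase HDAC6 (Homo sapiens), read by mobility shift assay (on this read-out higher numbers stand for weaker inhibition and lower numbers for stronger inhibition), compound 3 `O=C(NO)c1ccc(CN(Cc2ccccc2F)S(=O)(=O)c2cc(F)c(F)c(F)c2F)cc1` gives 10 nM, the second highest of the three numbers. Compound 1 `O=C(NO)c1ccc(CN(Cc2ccccc2)S(=O)(=O)c2cc(F)c(F)c(F)c2F)cc1` gives 5 nM in this assay, and compound 2 `O=C(NO)c1ccc(CN(Cc2cccc(F)c2)S(=O)(=O)c2cc(F)c(F)c(F)c2F)cc1` gives 14 nM. The steps among them are modest at most: a 2.0-fold higher number from compound 1 to compound 3 (0.30 log units; within the scatter), a 2.8-fold higher number from compound 1 to compound 2 (0.45 log units; beyond the scatter) and a 1.4-fold lower number from compound 2 to compound 3 (0.15 log units; within the scatter).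

Compound 4 `O=C(NO)c1ccc(CN(Cc2ccccn2)S(=O)(=O)c2cc(F)c(F)c(F)c2F)cc1` takes the change (pyridin-2-yl in place of 2-fluorophenyl on a saturated chain carbon bound to a sulfonamide nitrogen). Among the compounds with values here, none of the measured steps exchanges a carbon-only ring for one holding a nitrogen, so they bear on this change only loosely; they show that altering this ring shifted the numbers little, with the largest step being a 2.8-fold higher number from compound 1 to compound 2 (0.45 log units; beyond the scatter). A step of similar size is therefore expected, in either direction, with slightly higher numbers somewhat more likely: for compound 4 the expected step is a 1.5-fold higher number from compound 3 to compound 4 (0.18 log units; within the scatter). The estimate for compound 4 is 15 nM, within a range from 5 nM to 45 nM.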

Compound 4, half-maximal inhibitory concentration: 6 nM
Estimate against measurement, compound 4: 2.5-fold (0.40 log units) above; the range from low to high includes it.
By their numbers in this assay, from the lowest: compounds 1, 4, 3 and 2 (each within the scatter of the next, the first and the last beyond it).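

Pyridin-2-yl is accepted on this saturated chain carbon: the change from 2-fluorophenyl gives a 1.7-fold lower number from compound 3 to compound 4 (0.22 log units; within the scatter) in this assay and the change from phenyl gives a 1.2-fold higher number from compound 1 to compound 4 (0.08 log units; within the scatter), so in both comparisons a ring holding a nitrogen and a hydrogen-bond acceptor does not separate from a carbon-only ring. Only the comparison with 3-fluorophenyl shows a step beyond the scatter, a 2.3-fold lower number from compound 2 to compound 4 (0.37 log units; beyond the scatter), and it is a modest one. No supporting measurement is available to say why the nitrogen is accepted here.

The compounds shown leave open whether a ring with a second nitrogen, such as pyrimidinyl, would behave like pyridin-2-yl. They also leave open whether this position needs an aromatic ring at all, which a saturated group such as cyclohexyl or a chain ending in an amine could test.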